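Ester for benzylamide on the shared core

This account rests on a few compounds, and the source may have more. Where it says the series, first, only, none or still open, it means among the compounds named here.

Three compounds of the series have numbers in an assay on cells (Oocyte) for inhibition of Voltage-dependent T-type calcium channel subunit alpha-1H (Homo sapiens), tested at 100 uM; on this read-out higher numbers stand for more inhibition at the one concentration tested (going by the name of the read-out) and lower numbers for less inhibition. Compound 1 `CC(C)(C)OC(=O)NCCCCCN1C(Nc2ccc(-c3ccccc3)cc2)=Nc2ccccc2C1CC(=O)NCc1ccccc1` gives 91.2%. Compound 2 `COC(=O)CC1c2ccccc2N=C(NCCCCCN)N1c1ccc(-c2ccccc2)cc1` gives 97%, and compound 3 `COC(=O)CC1c2ccccc2N=C(NCCCCCNC(=O)OC(C)(C)C)N1c1ccc(-c2ccccc2)cc1` gives 92.2%. All three sit close together: compound 1 has the lowest of the three numbers, but its gap to compound 3 and its gap to compound 2 are both within the scatter, so no order among them can be read. For the measured compounds named here, the one measured single change is the Boc group added to the amine nitrogen, a number 4.8 percentage points lower from compound 2 to compound 3 (within the scatter), again within the scatter.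

Compound 4 `COC(=O)CC1c2ccccc2N=C(Nc2ccc(-c3ccccc3)cc2)N1CCCCCNC(=O)OC(C)(C)C` is the next compound. Relative to compound 1 it carries methoxy in place of benzylamino on a carbonyl carbon. Going by the values given here, no measured step touches the carbonyl end of the chain, so nothing speaks directly to this change; the only guide is that every variant measured so far gives a high number. The expected step is therefore none beyond the scatter, a number 0.8 percentage points higher from compound 1 to compound 4 (within the scatter). Compound 4 is estimated at 92%, in the range 80% to 99%.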

Compound 4, a percentage reported as inhibition, at one concentration (the size of the read-out at that concentration, not a potency): 96.5%
Compound 4: middle estimate off by 4.5 percentage points, on the low side; the measured number falls inside the stated range.
By their numbers in this assay, from the lowest: compounds 1, 3, 4 and 2 (each within the scatter of the next).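

On a carbonyl carbon whose other neighbour is a saturated chain carbon, methoxy in place of benzylamino gives a number 5.3 percentage points higher from compound 1 to compound 4 (within the scatter) in this assay. For the compounds shown here, this is the first measured step at this end of the molecule, and it shows that neither the six-membered aromatic ring of benzylamino nor its hydrogen-bond donor is needed for a high number at the one concentration tested, with the eight heavy atoms of that group reduced to the two of methoxy. No supporting data bear on this result, so it stays a plain observation.

The compounds shown leave open whether a carboxylic acid or a dimethylamino group on the same carbonyl carbon would keep the number this high. A single concentration also leaves open whether compound 1 and compound 4 differ in potency.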